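N-methylation of the imidazole headgroup in a piperazine series

The source may report more compounds than this note shows. Statements on the series, on what has been measured and on what is new or still open speak of the compounds shown alone.

Measured so far in an assay on isolated protein for displacement of a labelled ligand from Gonadotropin-releasing hormone receptor (Rattus norvegicus); a higher number here means a weaker inhibitor, a lower number a stronger inhibitor:
- compound 1 `Cc1nc(CN2CCN(c3cccc4[nH]c(-c5ccc(C(C)(C)C)cc5)nc34)CC2)c[nH]1`: 28 nM
- compound 2 `CCc1nc(C)c(CN2CCN(c3cccc4[nH]c(-c5ccc(C(C)(C)C)cc5)nc34)CC2)s1`: 120 nM
- compound 3 `CCCCn1cnc(CN2CCN(c3cccc4[nH]c(-c5ccc(C(C)(C)C)cc5)nc34)CC2)c1C`: 49 nM

Compound 1 gives the lowest of the three numbers in this assay. Its gap to compound 3 is within the scatter, so no order between the two can be claimed; its gap to compound 2 is beyond the scatter, a 4.3-fold higher number from compound 1 to compound 2 (0.63 log units; beyond the scatter).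

Compound 4 `Cc1nc(CN2CCN(c3cccc4[nH]c(-c5ccc(C(C)(C)C)cc5)nc34)CC2)cn1C` has not been measured. It differs from compound 1 by methyl in place of hydrogen on an aromatic nitrogen.

Going by the values given here, two measured steps bear on this change. The step of a 1.8-fold higher number from compound 1 to compound 3 (0.24 log units; within the scatter) adds a butyl to the same ring nitrogen together with a methyl on the ring, and stays within the scatter. Among the compounds with values here, the step of a 4.3-fold higher number from compound 1 to compound 2 (0.63 log units; beyond the scatter) replaces the whole ring and is the only change beyond the scatter. A methyl on the ring nitrogen is a smaller change than either, so compound 4 is expected to sit close to compound 1, with at most a small move toward higher numbers, a 1.3-fold higher number from compound 1 to compound 4 (0.10 log units; within the scatter).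

Compound 4 is therefore estimated at 35 nM in this assay, with a range of 15 nM to 90 nM.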

Compound 4, half-maximal inhibitory concentration in the Gonadotropin-releasing hormone receptor assay: 34 nM
Compound 4: middle estimate off by 1.0-fold (0.01 log units), on the high side; the measured number falls inside the stated range.
By their numbers in the Gonadotropin-releasing hormone receptor assay, from the lowest: compounds 1, 4 and 3 (each within the scatter of the next); then compound 2.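

In the Gonadotropin-releasing hormone receptor assay, compound 1 gives 28 nM and compound 4 gives 34 nM; methyl on the aromatic nitrogen, with no other change to the ring, stays within the scatter (a 1.2-fold higher number from compound 1 to compound 4 (0.08 log units; within the scatter)); earlier compounds altered this nitrogen only together with a second change, so the hydrogen on it can now be said not to be required for binding in this pair. Going by these compounds alone, also in the Gonadotropin-releasing hormone receptor assay, the 1,2-dimethyl-1H-imidazol-4-yl group cannot be separated from the 1-butyl-5-methyl-1H-imidazol-4-yl group (a 1.4-fold lower number from compound 3 to compound 4 (0.16 log units; within the scatter)) but stands apart from the 2-ethyl-4-methyl-1,3-thiazol-5-yl group (a 3.5-fold lower number from compound 2 to compound 4 (0.55 log units; beyond the scatter)), which leaves compound 2 as the only compound here beyond the scatter of the other three. In a physicochemical assay for solubility, at pH 7.4 (a lower number here means a less soluble compound, a higher number a more soluble compound), compound 1 gives 46 ug/mL and compound 4 gives 51 ug/mL, and the same methyl also stays within the scatter (a 1.1-fold higher number from compound 1 to compound 4 (0.04 log units; within the scatter)), so in this pair neither read-out separates the two compounds.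

Nothing at hand gives a reason for any of these numbers. Still open, on these data alone, is how far this nitrogen accepts groups other than methyl and butyl, such as a longer chain ending in an amine or a carboxylic acid, with the rest of the ring left as in compound 4.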